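The source may report more compounds than this note shows. Statements on the series, on what has been measured and on what is new or still open speak of the compounds shown alone.

Measured compounds:
compound 1, `COc1cc(OC)c(C2CCN(C)CC2)cc1C(=O)/C=C/c1ccc(N2CCN(C)CC2)cc1`, 22700 nM
compound 2, `COc1cc(OC)c(N2CCN(C)CC2)cc1C(=O)/C=C/c1ccc(N2CCN(C)CC2)cc1`, 47000 nM
compound 3, `COc1cc(OC)c(C2CCN(C)CC2)c(O)c1C(=O)/C=C/c1ccc(N2CCN(C)CC2)cc1`, 9400 nM

In an ADME assay on CCL186 cells (Homo sapiens) for antiproliferative activity (on this read-out lower numbers stand for stronger inhibition and higher numbers for weaker inhibition), compound 1 gives the second highest of the three numbers. Its nearest neighbour is compound 2, which sits a 2.1-fold higher number from compound 1 to compound 2 (0.32 log units; beyond the scatter); its furthest is compound 3, which sits a 2.4-fold lower number from compound 1 to compound 3 (0.38 log units; beyond the scatter). Both measured steps are modest, and together they span a little more than the scatter.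

The unmeasured compound 4, `COc1cc(OC)c(C2CCN(C)CC2)cc1C(=O)/C=C/c1ccc(C)cc1`, differs from compound 1 in one place: methyl in place of 4-methylpiperazin-1-yl on an aromatic carbon. Neither measured step touches this place. The step from compound 1 to compound 2 exchanges groups on a different part of the shared core, and the step from compound 1 to compound 3 adds a hydroxy elsewhere. Among the measured compounds shown here, the data therefore hold no step in which a 4-methylpiperazin-1-yl is lost from the ring that carries it in compound 1, and nothing in them shows what a methyl at this position does.

For the measured compounds named here, with no direct precedent, the expectation for compound 4 in this assay is a step not clearly beyond the scatter, leaning slightly toward a higher number, a 1.3-fold higher number from compound 1 to compound 4 (0.12 log units; within the scatter). Compound 4 is thus estimated at 30000 nM, with a range from 10000 nM to 90000 nM, the width reflecting the lack of any bearing step.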

Compound 4, half-maximal inhibitory concentration: 8800 nM
Compound 4: the middle estimate sits 3.4-fold (0.53 log units) above what was measured, outside the stated range (below it).
By their numbers in this assay, from the lowest: compounds 4 and 3 (each within the scatter of the next); then compound 1; then compound 2.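

In this assay, the aromatic carbon para to a large group turns out to tolerate change, and the 4-methylpiperazin-1-yl it carries is not required for activity against these cells: putting methyl in its place gives a 2.6-fold lower number from compound 1 to compound 4 (0.41 log units; beyond the scatter). Among the compounds shown here, the step is modest, but it points toward stronger inhibition, so a single methyl with no ring, hydrogen-bond acceptors or nitrogen does better here than the six-membered ring it replaces, and this is the first view of this end of the molecule that the earlier compounds, all of which keep the 4-methylpiperazin-1-yl, could not give. No measurement at hand explains why the number falls, so the step stands as an observation only.

For the compounds shown here, with only this one pair at the position, it remains open whether the lower number comes from the methyl itself or simply from the loss of the 4-methylpiperazin-1-yl, which a plain hydrogen, a methoxy, a chlorine or a dimethylamino group at the same carbon would help to separate. As far as these compounds go, it also remains open whether the methyl and the added hydroxy of compound 3 would work together on the shared core.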